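Fluoro step on an anilino and a benzylthio core

The source may hold more compounds than are shown below. What is called first, only, known or untested is meant among the compounds shown, and "the series" means these compounds.

Measured compounds:
compound 1 `Cn1cnc2c(Nc3ccccc3)ncnc21` gives 0%
compound 2 `Cn1cnc2c(Nc3ccc(F)cc3)ncnc21` gives 7%
compound 3 `Cn1cnc2c(SCc3ccccc3)ncnc21` gives 1%

All three values come from an assay on isolated protein for inhibition of Rho-associated protein kinase 1 (Homo sapiens), tested at 30 uM; on this read-out higher numbers stand for more inhibition at the one concentration tested (going by the name of the read-out) and lower numbers for less inhibition. From compound 1 to compound 2 the change is fluoro in place of hydrogen on an aromatic carbon; the step it made is a number 7 percentage points higher from compound 1 to compound 2 (within the scatter). Compound 3 carries a different core; how its core differs from that of compound 1 is not broken down here. Compound 4 `Cn1cnc2c(SCc3ccc(F)cc3)ncnc21` is not yet measured. From compound 3 to compound 4 the change is fluoro in place of hydrogen on an aromatic carbon, the same change seen from compound 1 to compound 2. In this assay compound 4 is therefore expected to give 4%, between 0% and 14%, a step of a number 3 percentage points higher from compound 3 to compound 4 (within the scatter), resting on the step from compound 1 to compound 2 lying within the scatter and on compound 3 giving 1%.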

Compound 4, a percentage reported as inhibition, at one concentration (the size of the read-out at that concentration, not a potency): 6%
Beside the measured number, compound 4's estimate is 2 percentage points below it, and the stated range covers the measured number.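

In this assay, fluoro in place of hydrogen on an aromatic carbon gives a step of a number 5 percentage points higher from compound 3 to compound 4 (within the scatter), and the two steps seen so far do not differ between the cores: the same change on two cores in this assay, a number 7 percentage points higher (within the scatter) from compound 1 to compound 2 and a number 5 percentage points higher (within the scatter) from compound 3 to compound 4, 2 percentage points apart, within the scatter of two such steps. The change therefore carries across these two cores without a visible difference, but both steps lie within the scatter, so neither core shows a real gain in inhibition from fluoro. Agreement between two steps this small says little about how the change would behave on any further core.

Going by these compounds, it remains open whether a different group on the same aromatic ring, such as an amine, a carboxylic acid or a longer chain, would move this assay beyond the scatter. On these data alone, with a single tested concentration, potency also remains unknown.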